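The compounds below may be only part of what the source reports. "The series", "measured", "known", "first", "only" and "open" are said of these compounds alone.

Compound 1 `Cc1nnc(N2CCC(C(=O)N3N=CC[C@H]3c3ccccc3)CC2)o1`: 1 h
Compound 2 `O=C(c1cn[nH]c1)N1CCC(C(=O)N2N=CCC2c2ccccc2)CC1`: 0.417 h
Compound 3 `O=C(c1c[nH]nn1)N1CCC(C(=O)N2N=CCC2c2ccccc2)CC1`: 0.417 h

All three values come from an ADME assay on the whole organism (Rattus norvegicus) for metabolic stability, at a dose of 1 mg/kg by the intravenous route; a lower number here means that the compound disappears faster, a higher number that the compound lasts longer. Compound 3 stands level with compound 2, and together they hold the lowest of the three numbers. Compound 1 is the only one set apart, and its gap to compound 3 lies beyond the scatter.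

The next structure is compound 4 `O=C(c1cocn1)N1CCC(C(=O)N2N=CCC2c2ccccc2)CC1`, which keeps the shared core and changes one group: 1,3-oxazol-4-yl in place of 1H-1,2,3-triazol-4-yl on a carbonyl carbon. Put simply, it has 1,3-oxazol-4-yl in place of 1H-1,2,3-triazol-4-yl on a carbonyl carbon.

For the measured compounds named here, one measured step bears on this, as it also swaps one five-membered aromatic ring for another at that carbonyl carbon: no change at the digits printed from compound 2 to compound 3 (within the scatter). Going by the values given here, that is only a single step, and no measured compound carries the 1,3-oxazol-4-yl group, so the guidance is thin. It gives no reason to expect a shift beyond the scatter in either direction.

The expected size is a 1.2-fold higher number from compound 3 to compound 4 (0.08 log units; within the scatter). For compound 4 the estimate is 0.5 h, with an expected range from 0.25 h to 1 h.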

Compound 4, half-life: 0.2 h
The estimate for compound 4 lay 2.5-fold (0.40 log units) above the measured number; measured number outside the range, below it.
By their numbers in this assay, from the lowest: compound 4; then compounds 2 and 3 (each within the scatter of the next); then compound 1.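

In this assay, the choice of five-membered aromatic ring on this carbonyl carbon now proves able to move the number: the earlier swap gave no change at the digits printed from compound 2 to compound 3 (within the scatter), but the 1,3-oxazol-4-yl group gives a 2.1-fold lower number from compound 3 to compound 4 (0.32 log units; beyond the scatter) and also a 2.1-fold lower number from compound 2 to compound 4 (0.32 log units; beyond the scatter) in the second comparison. The computed counts show that 1H-1,2,3-triazol-4-yl has 1 hydrogen-bond donor and 1,3-oxazol-4-yl has 0, but this difference merely accompanies the step and is not shown to drive it. No measurement shown gives a reason for the lower number.

Going by these compounds, it remains open whether a non-aromatic group on this carbonyl carbon, such as a methyl or a cyclopropyl, would stand with compound 4 or with compounds 2 and 3. Other five-membered aromatic rings, such as a thiazole, are likewise untested in the compounds shown here.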